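The source may hold more compounds than are shown below. What is called first, only, known or untested is meant among the compounds shown, and "the series" means these compounds.

Working notes on the series.

Compound 1 `N#Cc1c(-c2cc(Cl)c3[nH]ccc3c2)ccn2c(CC(F)(F)F)cnc12` is measured in a functional assay on CHO cells for agonist activity at metabotropic glutamate receptor 2 (Homo sapiens); on this read-out lower numbers stand for smaller maximal responses and higher numbers for larger maximal responses; in it compound 1 gives 277%. Compound 2 `N#Cc1c(-c2ccc3c(ccn3[C@H]3CC[C@H](O)CC3)c2)ccn2c(CC(F)(F)F)cnc12` rests on a different core, and the difference between the two cores is not broken down here. In this assay compound 2 gives 237%. Compound 3 `O[C@H]1CC[C@H](n2ccc3cc(-c4ccn5c(CC(F)(F)F)cnc5c4Cl)ccc32)CC1` follows from compound 2 by the change (chloro in place of cyano on an aromatic carbon). In this assay compound 3 gives 244%, so the step of a number 7 percentage points higher from compound 2 to compound 3 (within the scatter) stays within the scatter of the read-out. Compound 1 stands highest of the three measured numbers, with compound 3 nearest and compound 2 furthest, both gaps beyond the scatter.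

Compound 4 `FC(F)(F)Cc1cnc2c(Cl)c(-c3cc(Cl)c4[nH]ccc4c3)ccn12` is not yet measured. Among the compounds with values here, it follows from compound 1 by the change (chloro in place of cyano on an aromatic carbon), the same change at the same place as the one from compound 2 to compound 3. The earlier step of a number 7 percentage points higher from compound 2 to compound 3 (within the scatter) did not leave the scatter, and compound 1 starts from 277%, so an equally small step is expected here. The step from compound 1 to compound 4 is expected as a number 5 percentage points higher from compound 1 to compound 4 (within the scatter). Compound 4 is therefore estimated at 282%, with an expected range from 245% to 320%.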

Compound 4, largest response reached (Emax), in percent of the reference or control that the assay uses: 217%
For compound 4 the middle estimate is 65 percentage points above the measured one; the measured number lies below the stated range.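

In this assay the new step is a number 60 percentage points lower from compound 1 to compound 4 (beyond the scatter), so chloro in place of cyano on an aromatic carbon does not carry a fixed size from one core to another in this series. The two cores answer differently to the same change: the same change on two cores in this assay, a number 7 percentage points higher (within the scatter) from compound 2 to compound 3 and a number 60 percentage points lower (beyond the scatter) from compound 1 to compound 4, 67 percentage points apart, beyond the scatter of two such steps. This shows that, for these two pairs, the result of the change depends on the core that carries it; it does not show which part of the structures separating compound 1 from compound 2 decides the outcome, nor does a comparison of two pairs give a rule for any further core.

Open, going by these compounds, is whether a methyl group, a bromo group or an amine on the same aromatic carbon would separate the two cores in the same way as chloro does. Also open, on these data alone, is whether the difference between the two steps would hold in a read-out other than this largest response.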